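The compounds below may be only part of what the source reports. "The series", "measured", "known", "first", "only" and "open" are said of these compounds alone.

Four compounds share one core and differ only in the ring-bearing group carried on a saturated chain carbon bound to an aromatic carbon of that core. Compound 1 `CC(C)[C@@H](c1ccc(-c2ccc3cccc(F)c3c2)[nH]c1=O)[C@H]1OC(=O)NC1=O` was measured in an ADME assay on MDCK cells (Canis lupus familiaris) for permeability, in the apical to basolateral direction (on this read-out lower numbers stand for lower permeability and higher numbers for higher permeability), and gives 9.14 10^-6 cm/s. Compound 2 `CC(C)C(c1ccc(-c2ccc3cccc(F)c3c2)[nH]c1=O)C1C(=O)NC(=O)N1C` has no result in this assay, its entry reading "not determined" (no result reported), and the same is true of compound 3 `CC(C)C1(c2ccc(-c3ccc4ccccc4c3)[nH]c2=O)OC(=O)NC1=O`, whose entry reads "not determined" (no result reported), so compound 2 stands without a number of its own, and the only measured anchor among these compounds is compound 1.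

The step that the piece follows leads from compound 2 to compound 4 `CC(C)C(/C=C1\SC(=O)NC1=O)c1ccc(-c2ccc3cccc(F)c3c2)[nH]c1=O`. The change is a group of 8 heavy atoms (4 carbon, 1 nitrogen, 2 oxygen, 1 sulfur; one five-membered non-aromatic ring with 2 hetero atoms) in place of a group of 8 heavy atoms (4 carbon, 2 nitrogen, 2 oxygen; one five-membered non-aromatic ring with 2 hetero atoms), on a saturated chain carbon bound to an aromatic carbon and a saturated chain carbon. The group that leaves and the group that enters are of the same size, each with one five-membered non-aromatic ring holding two hetero atoms, and each with a single hydrogen-bond donor; the entering group brings one more double bond outside aromatic rings and one more hydrogen-bond acceptor, with a sulfur atom in place of one nitrogen.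

No measured pair among these compounds shows how such a change moves this assay, so the expectation for compound 4 rests on the one value known, that of compound 1, and on the modest size of the change. Compound 4 is therefore expected to give roughly 8 10^-6 cm/s, with a plausible range from 3 10^-6 cm/s to 20 10^-6 cm/s.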

Compound 4, apparent permeability: 15.4 10^-6 cm/s
For compound 4 the middle estimate is 1.9-fold (0.28 log units) below the measured one; low and high end bracket the measured number.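

Compound 2 has no single number in this assay, so the change from compound 2 to compound 4 cannot be read as a step. Nothing shown explains the value of compound 4. The compounds shown leave open how replacing the 3-methyl-2,5-dioxoimidazolidin-4-yl group with the sulfur-containing ring group moves this read-out.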